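A few compounds are considered here, and "the series" means these few. Any claim that something is new, unique, unknown or untested is made for them only; others in the source may bear on it.

Measured so far:
compound 1 `COC(=O)c1sc2cc(C#Cc3ccccc3F)cnc2c1N`: > 150000 nM
compound 2 `COC(=O)c1sc2cc(C#Cc3ccccc3OC)cnc2c1N`: > 47300 nM

In a functional assay on MCF7 cells (Homo sapiens) for inhibition, read by sulforhodamine B assay, with a stated time of 48 h (a lower number here means a stronger inhibitor of growth, a higher number a weaker inhibitor of growth), compound 1 gives only a limit, > 150000 nM. In this assay compound 2 likewise gives only a limit, > 47300 nM. Within the data shown here, the single step between measured compounds, methoxy in place of fluoro on an aromatic carbon, is a step that the two limits leave unreadable from compound 1 to compound 2; the limit of > 150000 nM in this assay, at which 1 of the 2 values shown sits, and the limit of > 47300 nM in this assay, at which 1 of the 2 values shown sits, leave its size unreadable. Compound 2 therefore stands at a limit, with no number that ranks it against compound 1.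

Compound 3 `COC(=O)c1sc2cc(C#Cc3ccsc3)cnc2c1N` differs from compound 2 by thiophen-3-yl in place of 2-methoxyphenyl on a triple-bonded carbon. Among the measured compounds shown here, no measured step bears on this exchange, and both measured values are limits, so no step beyond the scatter can be expected in this assay in either direction. For compound 3 the estimate in this assay is 100000 nM, ranging from 30000 nM to 300000 nM. The step from compound 2 to compound 3 is thus expected to be a step that the limit leaves unreadable from compound 2 to compound 3.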

Compound 3, concentration for 50% growth inhibition: 27700 nM
Estimate against measurement, compound 3: 3.6-fold (0.56 log units) above, and the stated range ends above it.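

Thiophen-3-yl on the triple-bonded carbon gives compound 3 the first number rather than a limit in this assay, and in place of 2-fluorophenyl it brings an at least 5.4-fold lower number from compound 1 to compound 3 (0.73 log units; beyond the scatter). In place of 2-methoxyphenyl it brings an at least 1.7-fold lower number from compound 2 to compound 3 (0.23 log units; that floor lies within the scatter), and this is only a floor, because compound 2 stands at a limit: the limit of > 47300 nM in this assay, at which 1 of the 3 values shown sits. The step from compound 1 is likewise only a floor, because compound 1 stands at a limit: the limit of > 150000 nM in this assay, at which 1 of the 3 values shown sits.

The true size of both steps stays open, as does any reason for them. The compounds shown also leave open whether a thiophen-2-yl, a pyridin-3-yl or an aminophenyl group on the same triple-bonded carbon would give a lower or a higher number than compound 3.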